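A few compounds are considered here, and "the series" means these few. Any claim that something is new, unique, unknown or untested is made for them only; others in the source may bear on it.

Among the measured compounds shown here, in a physicochemical assay for lipophilicity, read by HPLC, using the shake flask method (a lower number here means a more polar compound, a higher number a more lipophilic compound), three compounds have numbers so far. Compound 1 `CCCCCN(Cc1ccc(Cl)nc1)/C(C)=N/C#N` gives 2.37, compound 2 `C/C(=N\C#N)N(Cc1ccccc1)Cc1ccc(Cl)nc1` gives 2.11, and compound 3 `CC/C(=N\C#N)N(C)Cc1ccc(Cl)nc1` gives 1.12. Compound 3 is the lowest of the three, and its gap to each of the other two lies beyond the usual scatter.

Compound 4 `CC(C)C/C(=N\C#N)N(C)Cc1ccc(Cl)nc1` has not been measured yet. Its difference from compound 3 is isopropyl in place of methyl on a saturated chain carbon bound to a carbon with a double bond to nitrogen, which in words is isopropyl in place of methyl on a saturated chain carbon bound to a carbon with a double bond to nitrogen.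

For the measured compounds named here, only one measured step changes a single place, namely a number 0.26 log units lower from compound 1 to compound 2 (within the scatter), which lies within the scatter. It puts phenyl in place of butyl on a saturated chain carbon bound to an amine nitrogen, so it concerns a different place and a different exchange, and it is a weak guide here. Going by the values given here, no measured step covers the change at hand, so the expectation rests mainly on the structural change, which adds carbon and no hydrogen-bond donors or acceptors.

A rise beyond the scatter is therefore expected, and the expected step is a number 0.88 log units higher from compound 3 to compound 4 (beyond the scatter). For compound 4 the estimated value is 2, with an expected range from 1.6 to 2.4.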

Compound 4, partition coefficient: 1.75
For compound 4 the middle estimate is 0.25 log units above the measured one; the measured number falls inside the stated range.
By their numbers in this assay, from the lowest: compound 3; then compound 4; then compounds 2 and 1 (each within the scatter of the next).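

In this assay, putting isopropyl in place of methyl on a saturated chain carbon bound to a carbon with a double bond to nitrogen gives a number 0.63 log units higher from compound 3 to compound 4 (beyond the scatter). Among the compounds shown here, this is the first measured change at this place, and it shows that the number here can shift beyond the scatter when the group grows from 1 carbon to 3 carbons, whereas the only earlier step, a number 0.26 log units lower from compound 1 to compound 2 (within the scatter), concerns a different place and a different exchange and stays within the scatter. Nothing measured alongside these compounds gives a reason for the size of this step.

With only one exchange at this place, the compounds shown leave open whether a straight propyl group, a longer chain or a cyclopropyl ring would shift the number as far as isopropyl does, so it remains unclear whether branching matters or only the count of carbons. Also open, from the compounds shown here alone, are the numbers that a hydroxyl group, an amine or a carboxylic acid would give on this same carbon, and whether the exchange would give a similar step in compounds that differ elsewhere.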